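Diisopropylamino in place of (tert-butyl)amino in the series

A few compounds are considered here, and "the series" means these few. Any claim that something is new, unique, unknown or untested is made for them only; others in the source may bear on it.

- compound 1 `CC(=O)/C(=C\c1ccccc1)Oc1ccc(OCC(C)N(C)C)cc1` gives 3 mg/kg as its dose
- compound 2 `CC(=O)/C(=C\c1ccccc1)Oc1ccccc1OCCCNC(C)(C)C` gives 1.5 mg/kg as its dose

In a functional assay on the whole organism (heart) with Rattus norvegicus as the target (on this read-out lower numbers stand for an effect already at smaller amounts and higher numbers for an effect only at larger amounts of compound), compound 2 stands within the usual scatter of compound 1, so neither compound leads. Compound 3 `CC(=O)/C(=C\c1ccccc1)Oc1ccccc1OCCCN(C(C)C)C(C)C` carries diisopropylamino in place of (tert-butyl)amino on a saturated chain carbon, three bonds along the chain from an oxygen on an aromatic ring. Within the data shown here, no measured step sizes such a change. In this assay the expected step of a 1.3-fold higher number from compound 2 to compound 3 (0.12 log units; within the scatter) stays within the scatter, with no firm direction. Compound 3 is expected at 2 mg/kg within a range of 0.6 mg/kg to 6 mg/kg in this estimate.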

Compound 3, dose for half-maximal effect: 0.1 mg/kg
Estimate against measurement, compound 3: 20-fold (1.30 log units) above, and the stated range ends above it.
By their numbers in this assay, from the lowest: compound 3; then compounds 2 and 1 (each within the scatter of the next).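

The amine end of the chain proves sensitive: in this assay diisopropylamino in place of (tert-butyl)amino gives a 15-fold lower number from compound 2 to compound 3 (1.18 log units; beyond the scatter) and sets compound 3 apart from the other two compounds. This single change swaps a group with 1 hydrogen-bond donor for one with 0 and also adds carbon, and the pair cannot separate these differences. No evidence at hand accounts for the step.

As far as these compounds go, whether diethylamino or piperidin-1-yl at this place would give a similar number remains open. Also open, from the compounds shown here alone, is whether the step would hold with diisopropylamino on a longer chain.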